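The compounds below may be only part of what the source reports. "The series", "measured", "known", "first", "only" and "open" are said of these compounds alone.

Compound 1 `c1ccc(-c2nn3c(-c4ccncc4)nnc3s2)cc1` and compound 2 `Clc1ccc(-c2nn3c(-c4ccncc4)nnc3s2)c(Cl)c1` share one core. In a functional assay on the whole organism for inhibition, with Rattus norvegicus as the target, read by paw edema, with a stated time of 4 h, at a dose of 70 mg/kg by the oral route (a higher number here means more inhibition at the dose given (going by the name of the read-out), a lower number less inhibition), compound 1 gives 66.4% and compound 2 gives 69.3%, the two numbers lying within the scatter of each other, so neither stands apart. Compound 3 `Cc1ccccc1-c1nn2c(-c3ccncc3)nnc2s1` differs from compound 1 by methyl in place of hydrogen on an aromatic carbon. Among the compounds with values here, no measured pair shows this change directly. Given that compound 2 at 69.3% stays within the scatter of compound 1 after a larger change on the same ring, a step not beyond the scatter in either direction is expected in this assay. The expected step is a number 1.4 percentage points lower from compound 1 to compound 3 (within the scatter). Compound 3 is estimated at 65% in this assay, with a range from 50% to 78%.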

Compound 3, a percentage reported as inhibition, in the whole organism at one dose (the size of the read-out at that dose, not a potency): 79.8%
For compound 3 the middle estimate is 14.8 percentage points below the measured one; the whole stated range lies below it.
By their numbers in this assay, from the lowest: compounds 1 and 2 (each within the scatter of the next); then compound 3.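

Methyl in place of hydrogen on an aromatic carbon, ortho to a large group, gives a number 13.4 percentage points higher from compound 1 to compound 3 (beyond the scatter) in this assay. This single added carbon shows that the phenyl ring can respond to substitution at this position by more than the scatter, which compounds 1 and 2 alone did not reveal. Nothing at hand gives a reason for this step. On these data alone, it remains open whether the gain is specific to methyl or would also appear with ethyl, methoxy or chlorine at this position. Also open, as far as these compounds go, is whether methyl elsewhere on the ring would give a similar step.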